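This account rests on a few compounds, and the source may have more. Where it says the series, first, only, none or still open, it means among the compounds named here.

Compound 1 `CN1CCN(C(=S)SCc2ccc(C(=O)Nc3ccccc3N)cc2)CC1` is the reference point of this small set: in a functional assay on A-375 cells (Homo sapiens) for antiproliferative activity, read by CCK-8 assay, with a stated time of 72 h, tested at 2 uM (on this read-out higher numbers stand for a stronger effect at the one concentration tested and lower numbers for a weaker effect), compound 1 gives 36.6%. Compound 2 `Nc1ccccc1NC(=O)c1ccc(CSC(=S)N2CCN(C3CCCCC3)CC2)cc1` differs from it only at the amine nitrogen in the ring, where cyclohexyl replaces methyl, and in this assay compound 2 gives 31.7%. Among the compounds with values here, the step of a number 4.9 percentage points lower from compound 1 to compound 2 (within the scatter) is within the scatter, so compound 2 and compound 1 stand together on the numbers so far and neither can be called the weaker of the two.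

Compound 3 `Nc1ccccc1NC(=O)c1ccc(CSC(=S)N2CCN(Cc3ccccc3)CC2)cc1` is the next member. Its relation to compound 2 is benzyl in place of cyclohexyl on an amine nitrogen in a ring. Within the data shown here, the only measured step that bears on this change is the one at the same ring nitrogen, a number 4.9 percentage points lower from compound 1 to compound 2 (within the scatter), and that step was within the scatter. Among the measured compounds shown here, with one step of that size as the sole guide, no change beyond the scatter is expected in this assay for compound 3, in either direction. The step from compound 2 to compound 3 is therefore estimated at a number 1.3 percentage points higher from compound 2 to compound 3 (within the scatter). For compound 3 the expected value in this assay is 33%, with a range from 20% to 47%.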

Compound 3, a percentage reported as inhibition, at one concentration (the size of the read-out at that concentration, not a potency): 10.6%
The estimate for compound 3 lay 22.4 percentage points above the measured number, outside the stated range (below it).
By their numbers in this assay, from the lowest: compound 3; then compounds 2 and 1 (each within the scatter of the next).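

In this assay the group on the amine nitrogen in the ring turns out to matter: benzyl in place of cyclohexyl gives a number 21.1 percentage points lower from compound 2 to compound 3 (beyond the scatter) and, measured against methyl, phenyl in place of hydrogen on the saturated chain carbon bound to that nitrogen gives a number 26 percentage points lower from compound 1 to compound 3 (beyond the scatter). Methyl and cyclohexyl stand together on the numbers, so compound 3 alone is set apart, and the change from compound 2 brings a six-membered aromatic ring of carbon only where a non-aromatic one stood, along with one more carbon. Nothing at hand accounts for why this change comes with the lower number.

Because the ring type and the carbon count change together, these three compounds cannot say which of the two goes with the step; a cyclohexylmethyl group or a phenyl set directly on the nitrogen would pull them apart. Also open, on these data alone, is whether the step is tied to benzyl itself or extends to other aromatic groups on this nitrogen, such as a pyridylmethyl group or a longer phenylethyl chain.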